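Aryl ketone variation at the carbonyl of the shared core

The compounds below may be only part of what the source reports. "The series", "measured", "known", "first", "only" and "open" are said of these compounds alone.

Measured so far:
compound 1, `O=C(C=CNc1cc(-c2ccccc2)nn1-c1ccccc1)c1cccs1`, 15400 nM
compound 2, `O=C(C=CNc1cc(-c2ccccc2)nn1-c1ccccc1)c1ccc(Cl)cc1`, 8070 nM
compound 3, `O=C(C=CNc1cc(-c2ccccc2)nn1-c1ccccc1)c1ccc(F)cc1`, 9180 nM

All three numbers come from a functional assay on MCF7 cells (Homo sapiens) for inhibition, read by MTT assay, with a stated time of 48 h; a higher number here means a weaker inhibitor, a lower number a stronger inhibitor. The three compounds share one core and differ only in the ring on the carbonyl carbon. Compound 3 sits within the scatter of both neighbours: the step of a 1.1-fold higher number from compound 2 to compound 3 (0.06 log units; within the scatter) is small, and the step of a 1.7-fold lower number from compound 1 to compound 3 (0.22 log units; within the scatter) is also within the scatter. The step of a 1.9-fold lower number from compound 1 to compound 2 (0.28 log units; within the scatter) closes the triangle. Nothing among these three separates any ring from another beyond the usual spread of repeats.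

Compound 4, `COc1ccc(C(=O)C=CNc2cc(-c3ccccc3)nn2-c2ccccc2)cc1`, is not yet measured. It differs from compound 3 by methoxy in place of fluoro on an aromatic carbon.

For the measured compounds named here, the steps that bear on this change are the two that swap the ring or its substituent on the carbonyl carbon: a 1.1-fold higher number from compound 2 to compound 3 (0.06 log units; within the scatter) and a 1.7-fold lower number from compound 1 to compound 3 (0.22 log units; within the scatter). Both are within the scatter, so the numbers give no sign that changing this position moves the read-out. On that basis a step of about a 1.1-fold lower number from compound 3 to compound 4 (0.03 log units; within the scatter) is expected, that is, no change beyond the scatter in either direction. The estimate for compound 4 in this assay is 8500 nM, with a range from 4000 nM to 18000 nM.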

Compound 4, half-maximal inhibitory concentration: 1290 nM
The estimate for compound 4 lay 6.6-fold (0.82 log units) above the measured number; measured number outside the range, below it.
By their numbers in this assay, from the lowest: compound 4; then compounds 2, 3 and 1 (each within the scatter of the next).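

In this assay the ring on the carbonyl carbon proves able to move the read-out, which the first three compounds gave no sign of: methoxy in place of fluoro gives a step beyond the scatter (a 7.1-fold lower number from compound 3 to compound 4 (0.85 log units; beyond the scatter)), and methoxy in place of chloro does the same (a 6.3-fold lower number from compound 2 to compound 4 (0.80 log units; beyond the scatter)). The substituent on this aromatic carbon therefore matters, although fluoro and chloro stay within the scatter of each other, and the change from the thiophen-2-yl ring to 4-methoxyphenyl gives the largest step in the set (a 12-fold lower number from compound 1 to compound 4 (1.08 log units; beyond the scatter)), leaving compound 4 as the strongest inhibitor of the four, with steps to all the others beyond the scatter. No measurement shown accounts for the size of these steps.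

The compounds shown leave open whether the step belongs to methoxy alone or extends to related groups at the same place, such as ethoxy, hydroxy or dimethylamino. They also leave open whether a second methoxy on the same ring would add to the step or lose it.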